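The source may hold more compounds than are shown below. What is called first, only, known or untested is meant among the compounds shown, and "the series" means these compounds.

Of the compounds shown here, two of a shared core have been measured so far. Compound 1 `COc1cccc(OC)c1OCCNCCOc1ccccc1OCc1cccc(Cl)c1` gives 5900 nM in a functional assay on PC-3 cells (Homo sapiens) for cytotoxicity, read by sulforhodamine B assay; on this read-out higher numbers stand for weaker inhibition of growth and lower numbers for stronger inhibition of growth. For the measured compounds named here, compound 2 `COc1cccc(OC)c1OCCNCCOc1ccccc1OCc1cccc([N+](=O)[O-])c1` gives 13200 nM; compound 2 therefore stands at the highest of the two numbers, and the single step between them, a 2.2-fold higher number from compound 1 to compound 2 (0.35 log units; beyond the scatter), came with a nitro in place of a chloro on an aromatic carbon. Compound 3 `COc1cccc(OC)c1OCCNCCOc1ccccc1OCc1ccc(OC(C)C)cc1` differs from compound 2 as follows: 4-isopropoxyphenyl in place of 3-nitrophenyl on a saturated chain carbon bound to an oxygen on an aromatic ring. Going by the values given here, no measured step involves the group that enters here; the one known step only shows that exchanging a small substituent on that ring moved the number modestly. A step of similar modest size, and probably back toward the lower number, is expected for compound 3, about a 1.7-fold lower number from compound 2 to compound 3 (0.22 log units; within the scatter). For compound 3 the estimate is 8000 nM, with the likely range from 3000 nM to 25000 nM.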

Compound 3, concentration for 50% growth inhibition: 2000 nM
The estimate for compound 3 lay 4.0-fold (0.60 log units) above the measured number, outside the stated range (below it).
By their numbers in this assay, from the lowest: compound 3; then compound 1; then compound 2.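

In this assay, putting 4-isopropoxyphenyl in place of 3-nitrophenyl gives a 6.6-fold lower number from compound 2 to compound 3 (0.82 log units; beyond the scatter) and putting it in place of 3-chlorophenyl gives a 3.0-fold lower number from compound 1 to compound 3 (0.47 log units; beyond the scatter) in the same direction. This position, on a saturated chain carbon bound to an oxygen on an aromatic ring, can therefore carry a group that gives a lower number than either earlier compound, so the two earlier values did not mark the limit of what the shared core can reach. Nothing available here accounts for the fall in the number.

In this change, the substituent and its place on the ring differ together, so the two cannot be told apart. On these data alone, it also remains open how the number would respond to a methoxy group or a longer butoxy chain in place of the isopropoxy group.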